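Amide aryl variation on the shared flavonol core

The compounds below may be only part of what the source reports. "The series", "measured", "known", "first", "only" and "open" are said of these compounds alone.

Among the compounds with values here, compound 3 `O=C(Nc1cccc(-c2oc3cc(-c4ccc(F)cc4)ccc3c(=O)c2O)c1)c1ccc(Cl)nc1` gives 1760 nM in a functional assay on MDA-MB-231 cells (Homo sapiens) for antiproliferative activity, read by CCK-8 assay, with a stated time of 72 h (on this read-out lower numbers stand for stronger inhibition and higher numbers for weaker inhibition), the lowest of the three numbers so far. Compound 1 `Cc1ccc(C(=O)Nc2cccc(-c3oc4cc(-c5ccc(F)cc5)ccc4c(=O)c3O)c2)cc1` gives 4350 nM and compound 2 `O=C(Nc1cccc(-c2oc3cc(-c4ccc(F)cc4)ccc3c(=O)c2O)c1)c1ccc(Cl)cc1` gives 12800 nM. Both benzamides sit above compound 3: a 2.5-fold lower number from compound 1 to compound 3 (0.39 log units; beyond the scatter) and a 7.3-fold lower number from compound 2 to compound 3 (0.86 log units; beyond the scatter); within the benzamides, a 2.9-fold higher number from compound 1 to compound 2 (0.47 log units; beyond the scatter).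

Compound 4 `O=C(Nc1cccc(-c2oc3cc(-c4ccc(F)cc4)ccc3c(=O)c2O)c1)c1ccc([N+](=O)[O-])cc1` returns from the pyridyl amide to a benzamide: 4-nitrophenyl in place of 6-chloropyridin-3-yl on a carbonyl carbon. The two steps into compound 3 bear on this, both gains of modest size on leaving a carbon-only ring for the chloropyridyl; reversing that direction, a modest rise in this assay is expected for compound 4, of about a 2.8-fold higher number from compound 3 to compound 4 (0.45 log units; beyond the scatter). Compound 4 is estimated at 5000 nM, with a range from 1500 nM to 16000 nM.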

Compound 4, half-maximal inhibitory concentration: 14700 nM
The estimate for compound 4 lay 2.9-fold (0.47 log units) below the measured number; the measured number falls inside the stated range.
By their numbers in this assay, from the lowest: compound 3; then compound 1; then compounds 2 and 4 (each within the scatter of the next).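

In this assay, 4-nitrophenyl on the carbonyl carbon gives up the advantage of 6-chloropyridin-3-yl, with an 8.4-fold higher number from compound 3 to compound 4 (0.92 log units; beyond the scatter), so the pyridyl amide now stands clear of three benzamides rather than two. Among the benzamides, nitro and chloro on the aromatic carbon cannot be told apart, with a 1.1-fold higher number from compound 2 to compound 4 (0.06 log units; within the scatter), while methyl keeps the lower number against nitro, with a 3.4-fold higher number from compound 1 to compound 4 (0.53 log units; beyond the scatter). Open, going by these compounds, is whether an unsubstituted pyridin-3-yl, or a benzamide carrying an amine or a carboxylic acid in place of methyl, would reach the level of compound 3. Nothing available gives a reason for these differences.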